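Chloro in Place of Methyl on the Benzyl Arm

The source may hold more compounds than are shown below. What is called first, only, known or untested is meant among the compounds shown, and "the series" means these compounds.

Compound 1 `O=c1ccoc2cc(OCc3cn(Cc4ccccc4)nn3)ccc12` gives only the assay limit > 300000 nM in an ADME assay on L02 cells (Homo sapiens) for cytotoxicity, read by MTT assay, with a stated time of 48 h; on this read-out higher numbers stand for weaker inhibition and lower numbers for stronger inhibition.
Compound 2 `Cc1cccc(Cn2cc(COc3ccc4c(=O)ccoc4c3)nn2)c1` gives only the assay limit > 300000 nM in this assay.
Compound 3 `Cc1ccc(Cn2cc(COc3ccc4c(=O)ccoc4c3)nn2)cc1` gives only the assay limit > 300000 nM in this assay.

Compound 3 stands where every measured compound stands: at the limit of the assay, with no number of its own. The piece turns on the step to compound 4 `O=c1ccoc2cc(OCc3cn(Cc4ccc(Cl)cc4)nn3)ccc12`, which differs from compound 3 by chloro in place of methyl on an aromatic carbon. Three measured steps could bear on such a change, but none of them can be read: the step that the two limits leave unreadable from compound 1 to compound 2, the step that the two limits leave unreadable from compound 1 to compound 3 and the step that the two limits leave unreadable from compound 2 to compound 3 each run from one limit to another, so their size is hidden. What the data do show is the limit of > 300000 nM in this assay, at which 3 of the 3 values shown sit, and this is the only footing for any expectation. On that footing the step that the limit leaves unreadable from compound 3 to compound 4 is expected to be none that can be seen, and compound 4 is expected to give 350000 nM, within a range from 150000 nM to 1000000 nM, with a strong chance that the assay again reports only its limit.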

Compound 4, half-maximal inhibitory concentration: > 300000 nM
Compound 4 was reported as a limit (the forecaster's own chance of this, stated with the estimate: 80%); the middle value does not contradict the limit.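

In this assay compound 4 gives > 300000 nM, which is a limit of the assay. No step from compound 1, compound 2 or compound 3 to compound 4 can be read, and the four compounds stand alike: the limit of > 300000 nM in this assay, at which 4 of the 4 values shown sit.

The compounds shown leave open whether hydrogen, methyl or chloro on the benzyl arm makes any difference to this read-out.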